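Removing one terminal carboxy group from the triaryl diketone series

The source may hold more compounds than are shown below. What is called first, only, known or untested is meant among the compounds shown, and "the series" means these compounds.

Compound 1 `O=C(O)c1ccc(C(=O)c2ccc(C(=O)c3ccc(C(=O)O)cc3)cc2)cc1` carries a carboxy group at each end of its core. In an assay on CHO cells for inhibition of 3-oxo-5-alpha-steroid 4-dehydrogenase 2 (Homo sapiens) (a lower number here means a stronger inhibitor, a higher number a weaker inhibitor), compound 1 gives 1000 nM, the highest number among the three measured compounds. Compound 2 `O=C(O)c1ccc(C(=O)c2ccc(C(=O)c3ccc(C(F)(F)F)cc3)cc2)cc1` keeps one carboxy and replaces the other with trifluoromethyl; in this assay compound 2 gives 30 nM, a change described as a 33-fold lower number from compound 1 to compound 2 (1.52 log units; beyond the scatter). Compound 3 `Cc1ccc(Cc2ccc(C(=O)c3ccc(C(=O)O)cc3)cc2)cc1` differs from compound 1 in more than one place; in this assay compound 3 gives 15 nM, so both compounds that retain only a single carboxy sit well lower than compound 1.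

Compound 4 `O=C(O)c1ccc(C(=O)c2ccc(C(=O)Cc3ccccc3)cc2)cc1` has not yet been measured. The change from compound 1 is benzyl in place of 4-carboxyphenyl on a carbonyl carbon, leaving the carboxyphenyl ketone on the other side of the core intact. Among the compounds with values here, the one step that bears on it directly is the loss of a terminal carboxy from compound 1 to compound 2, which was large; compound 3 points the same way. A step of similar size toward a lower number is therefore expected in this assay, as a 20-fold lower number from compound 1 to compound 4 (1.30 log units; beyond the scatter). Compound 4 is estimated at 50 nM, within 10 nM to 250 nM.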

Compound 4, inhibition constant: 40 nM
Beside the measured number, compound 4's estimate is 1.3-fold (0.10 log units) above it; the range from low to high includes it.
By their numbers in this assay, from the lowest: compounds 3, 2 and 4 (each within the scatter of the next, the first and the last beyond it); then compound 1.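

In this assay, benzyl in place of 4-carboxyphenyl on this carbonyl carbon gives a 25-fold lower number from compound 1 to compound 4 (1.40 log units; beyond the scatter), so the whole 4-carboxyphenyl can be given up here, not only its carboxy. The earlier step at this end exchanged the carboxy alone and left the aromatic ring bonded directly to the carbonyl, whereas benzyl also changes how that ring is attached, and the step is still large. No measured evidence bears on the reason for this step.

The compounds shown leave open how much of the step belongs to the loss of the carboxy and how much to the added methylene, which a plain phenyl on the same carbonyl carbon would help to separate. Also open, as far as these compounds go, is how a longer chain such as 2-phenylethyl, or an amine, would read at this carbonyl carbon in this assay.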